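The source may report more compounds than this note shows. Statements on the series, on what has been measured and on what is new or still open speak of the compounds shown alone.

Among the measured compounds shown here, compound 3 `COc1ccc(Oc2ccc([N+](=O)[O-])cc2C(=O)Nc2ccc(F)cc2)cc1` stands second highest of the three numbers measured so far in a functional assay (Homo sapiens) for inhibition, using a membrane potential dye, in the presence of a further agent that is not named here; on this read-out lower numbers stand for stronger inhibition and higher numbers for weaker inhibition; compound 3 gives 7200 nM. Its nearest neighbour is compound 1 `COc1ccc(Oc2ccc([N+](=O)[O-])cc2C(=O)Nc2ccc(Cl)cc2)cc1`, which gives 10100 nM, the two separated only by a 1.4-fold lower number from compound 1 to compound 3 (0.15 log units; within the scatter). The furthest is compound 2 `COc1ccc(Oc2ccc([N+](=O)[O-])cc2C(=O)Nc2ccc(S(N)(=O)=O)cc2)cc1`, which gives 1800 nM, the gap being a 4.0-fold higher number from compound 2 to compound 3 (0.60 log units; beyond the scatter).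

Compound 4 `COc1ccc(Oc2ccc([N+](=O)[O-])cc2C(=O)Nc2cccc(S(N)(=O)=O)c2)cc1` differs from compound 3 by 3-sulfamoylphenyl in place of 4-fluorophenyl on an amide-type nitrogen. For the measured compounds named here, two measured steps bear on this: the exchange of a halogen for sulfamoyl, a 5.6-fold lower number from compound 1 to compound 2 (0.75 log units; beyond the scatter), and the reverse exchange, a 4.0-fold higher number from compound 2 to compound 3 (0.60 log units; beyond the scatter); both are modest, beyond the scatter, and both favour the sulfamoyl compound. Going by the values given here, no measured compound carries a 3-sulfamoylphenyl, so this particular placement is untested and the size is less certain. A step of similar direction and somewhat smaller size is nonetheless expected, a 2.9-fold lower number from compound 3 to compound 4 (0.46 log units; beyond the scatter). Compound 4 is therefore estimated at 2500 nM, with a range from 900 nM to 7000 nM.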

Compound 4, half-maximal inhibitory concentration: 9900 nM
For compound 4 the middle estimate is 4.0-fold (0.60 log units) below the measured one; measured number outside the range, above it.
By their numbers in this assay, from the lowest: compound 2; then compounds 3, 4 and 1 (each within the scatter of the next).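

In this assay, the benefit of sulfamoyl depends on its placement: 3-sulfamoylphenyl in place of 4-sulfamoylphenyl on the amide-type nitrogen gives a 5.5-fold higher number from compound 2 to compound 4 (0.74 log units; beyond the scatter). The 3-sulfamoylphenyl compound cannot be separated from the halogen compounds, with a 1.4-fold higher number from compound 3 to compound 4 (0.14 log units; within the scatter) and a 1.0-fold lower number from compound 1 to compound 4 (0.01 log units; within the scatter), so among these four compounds the presence of sulfamoyl alone does not set compound 2 apart, as compound 4 carries it without the same result. No measured evidence here accounts for the difference between the two placements.

Going by these compounds, it remains open whether the result for compound 2 is specific to sulfamoyl or would also hold for a carboxylic acid or an acetamide at the same place on the phenyl ring. Whether a methyl group on the sulfamoyl nitrogen would preserve it is also unresolved.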